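Second Trifluoromethyl Group and Cytotoxicity in Mouse Macrophages

The source may hold more compounds than are shown below. What is called first, only, known or untested is meant among the compounds shown, and "the series" means these compounds.

Measured compounds:
compound 1, `Cc1cc(NC(=O)c2cccc(C(F)(F)F)c2)ccc1NS(C)(=O)=O`: 110000 nM
compound 2, `Cc1cc(NC(=O)c2cc(C(F)(F)F)cc(C(F)(F)F)c2)ccc1NS(C)(=O)=O`: a limit of the assay, > 250000 nM
compound 3, `CCS(=O)(=O)Nc1ccc(NC(=O)c2cccc(C(F)(F)F)c2)cc1OC`: 84800 nM

Three compounds were tested in an ADME assay on RAW264.7 cells (Mus musculus) for cytotoxicity, read by MTT assay, with a stated time of 48 h; a lower number here means a stronger inhibitor, a higher number a weaker inhibitor. Compound 1 gives 110000 nM. For compound 2 the assay reports only a limit, > 250000 nM, and no number. Compound 3 gives 84800 nM, and this number and that of compound 1 lie within the scatter of each other, so no order between them is claimed. How the core of compound 3 differs from the core of compound 1 is not broken down here.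

Compound 2 differs from compound 1 by trifluoromethyl in place of hydrogen on an aromatic carbon. The step of an at least 2.2-fold higher number from compound 1 to compound 2 (0.35 log units; beyond the scatter) runs toward weaker inhibition and is known only as a bound, since compound 2 sits at the limit of > 250000 nM in this assay, at which 1 of the 3 values shown sits.

Compound 4, `CCS(=O)(=O)Nc1ccc(NC(=O)c2cc(C(F)(F)F)cc(C(F)(F)F)c2)cc1OC`, has not yet been measured. It stands to compound 3 exactly as compound 2 stands to compound 1: trifluoromethyl in place of hydrogen on an aromatic carbon, the same change at the same kind of place. Resting on an at least 2.2-fold higher number from compound 1 to compound 2 (0.35 log units; beyond the scatter), the expected step is a 2.4-fold higher number from compound 3 to compound 4 (0.37 log units; beyond the scatter). Compound 4 is therefore estimated at 200000 nM, with a likely range from 100000 nM to 450000 nM, and there is a real chance that for compound 4 the assay will again report only a limit rather than a number.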

Compound 4, half-maximal inhibitory concentration: > 250000 nM
Compound 4 was reported as a limit; the forecaster's own chance of this, stated with the estimate: 45%; at least 1.2-fold (0.09 log units) between middle value and limit.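

In this assay compound 4 gives only a limit of the assay, > 250000 nM, and not a number. The second trifluoromethyl group on the core of compound 3 produces an at least 2.9-fold higher number from compound 3 to compound 4 (0.46 log units; beyond the scatter), which runs toward weaker inhibition, the same direction as on the core of compound 1, so on the two cores shown the direction of the change carries over: the same change on two cores in this assay, an at least 2.2-fold higher number (0.35 log units; beyond the scatter) from compound 1 to compound 2 and an at least 2.9-fold higher number (0.46 log units; beyond the scatter) from compound 3 to compound 4; the limit leaves it open whether they differ. What does not carry over is a size, as both steps are known only as bounds that end at one and the same limit, and the series therefore cannot show whether the change counts for the same amount on both cores or how far each step really reaches: the limit of > 250000 nM in this assay, at which 2 of the 4 values shown sit.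

The compounds shown leave open whether a different group in place of that hydrogen on the aromatic carbon, such as a chlorine atom or a nitrile, would move the number in the same direction. They also leave open how the same trifluoromethyl change would behave on a core that carries an amine or a carboxylic acid.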